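The compounds below may be only part of what the source reports. "The series", "measured", "known", "first", "only" and "open" are said of these compounds alone.

Compound 1 `COc1cc(C(=O)O)ccc1OCCCCOc1ccc(C(=O)C(C)C)c(O)c1C` gives the lowest number of the three in an assay on HEK293 cells for positive allosteric modulation of metabotropic glutamate receptor 2 (Rattus norvegicus), read by thallium flux, with a stated time of 2.5 min (on this read-out higher numbers stand for an effect only at larger amounts of compound and lower numbers for an effect already at smaller amounts), at 113 nM. Compound 3 `Cc1cc(C(=O)O)ccc1OCCCCOc1ccc(C(=O)C(C)C)c(O)c1C` gives 234 nM, and compound 2 `COc1ccc(C(=O)O)cc1OCCCCOc1ccc(C(=O)CC2CCCC2)c(O)c1C` gives 425 nM. Going by the values given here, the only single-point step, a 2.1-fold higher number from compound 1 to compound 3 (0.32 log units; beyond the scatter), concerns the aromatic substituent and not the ketone side chain. Compound 4 `COc1cc(C(=O)O)ccc1OCCCCOc1ccc(C(C)=O)c(O)c1C` differs from compound 1 by methyl in place of isopropyl on a carbonyl carbon. Among the compounds with values here, no measured step touches the acyl group; compound 2 carries a different acyl group but also differs elsewhere, so its value alone cannot isolate that change. With the acyl group shortened, a modest rise in the number is expected, though the direction remains uncertain. Compound 4 is therefore expected at about 250 nM, within 80 nM to 800 nM, meaning an expected 2.2-fold higher number from compound 1 to compound 4 (0.34 log units; beyond the scatter).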

Compound 4, half-maximal effective concentration: 161 nM
Beside the measured number, compound 4's estimate is 1.6-fold (0.19 log units) above it; low and high end bracket the measured number.
By their numbers in this assay, from the lowest: compounds 1, 4, 3 and 2 (each within the scatter of the next, the first and the last beyond it).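

Shortening isopropyl to methyl on the carbonyl carbon gives a 1.4-fold higher number from compound 1 to compound 4 (0.15 log units; within the scatter) and is the first step in the series read at the acyl group. With the methoxy and the carboxylic acid held constant, the isopropyl can therefore be replaced by methyl without a change that stands out from the scatter. No measured evidence bears on the reason for this result. Open, going by these compounds, is whether a phenyl group, an amine or a longer chain on that carbonyl carbon would shift the number. Also open, on these data alone, is whether the same replacement behaves alike with methyl in place of methoxy on the aromatic carbon.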